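The compounds below may be only part of what the source reports. "The series", "measured", "known", "first", "only" and "open" are said of these compounds alone.

In a physicochemical assay for lipophilicity, read by HPLC, measured as chromatographic lipophilicity, at pH 7.4 (a higher number here means a more lipophilic compound, a lower number a more polar compound), two compounds have been measured so far. Compound 1 (`O=C(C1CCOC1)N1N=CCC1c1ccccc1`) gives 3, the higher of the two numbers. Compound 2 (`CC(=O)N1CCC(C(=O)N2N=CC[C@H]2c2ccccc2)CC1`) gives 2.5, a gap beyond the usual scatter. Compound 3 (`CC(C)(CO)C(=O)N1N=CCC1c1ccccc1`) has not yet been measured. It departs from compound 1 at a single place, with 1-(hydroxymethyl)-1-methylethyl in place of oxolan-3-yl on a carbonyl carbon. For the measured compounds named here, no measured pair differs at one place only, so the data offer no direct guide to the size of this change. Judged from the counted difference alone, a modest move toward lower numbers in this assay seems likely. The expected step is a number 0.30 log units lower from compound 1 to compound 3 (within the scatter), close to the edge of the scatter. For compound 3 the estimated value is 2.7, with an expected range from 2.2 to 3.2.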

Compound 3, distribution coefficient: 3.4
Beside the measured number, compound 3's estimate is 0.70 log units below it, outside the stated range (above it).
By their numbers in this assay, from the lowest: compound 2; then compound 1; then compound 3.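

In this assay the exchange of oxolan-3-yl for 1-(hydroxymethyl)-1-methylethyl on a carbonyl carbon gives a number 0.40 log units higher from compound 1 to compound 3 (beyond the scatter) as the first one-place step available at this position. Here the open chain replaces the ring at an equal counted heavy-atom size, and the hydrogen-bond donor it brings does not go with a lower number in this single pair. Nothing measured here accounts for the direction of this step.

Whether the rise belongs to the open chain or to its hydroxyl stays open, since no compound shown carries an open chain without the hydroxyl, such as tert-butyl, on that carbonyl carbon. The compounds also leave open how an amine or a carboxylic acid at this place would move the number.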